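The compounds below may be only part of what the source reports. "The series", "measured", "known", "first", "only" and "open" are said of these compounds alone.

Measured in a physicochemical assay for solubility, measured as kinetic solubility; on this read-out lower numbers stand for lower solubility and higher numbers for higher solubility:
- Compound 1 `C[C@H](NC(=O)c1cc(C(F)(F)F)ccc1Oc1ccccc1)c1cccc(S(C)(=O)=O)c1`: 57000 nM
- Compound 2 `O=C(N[C@@H](CO)c1cccc(Cl)c1)[C@H]1CC(F)(F)CC[C@@H]1c1ccccc1`: 318000 nM
- Compound 3 `CS(=O)(=O)c1cccc(CNC(=O)c2cc(C(F)(F)F)ccc2Sc2ccccc2)c1`: 34000 nM

The number for compound 3 lies within the usual scatter of the number for compound 1, so these two cannot be told apart. Compound 2 gives a higher number than compound 3, and that gap lies beyond the scatter.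

The next structure is compound 4 `CS(=O)(=O)c1cccc(CNC(=O)c2cc(C(F)(F)F)ccc2Oc2ccccc2)c1`. It carries phenoxy in place of the phenylsulfanyl of compound 3, on an aromatic carbon that is ortho to a large group and para to a trifluoromethyl group: phenoxy in place of phenylsulfanyl on an aromatic carbon.

Among the measured compounds shown here, no measured pair here differs in just one place, so the size of this step has no direct precedent. The closest guide is compound 1, which also carries phenoxy and gives 57000 nM, although it differs from compound 4 elsewhere. The expected change, a 1.3-fold higher number from compound 3 to compound 4 (0.12 log units; within the scatter), is small and not beyond the scatter. For compound 4 in this assay, the estimated value is 45000 nM, with an expected range of 20000 nM to 100000 nM.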

Compound 4, solubility: 23000 nM
Compound 4: the middle estimate sits 2.0-fold (0.29 log units) above what was measured; the measured number falls inside the stated range.
By their numbers in this assay, from the lowest: compounds 4, 3 and 1 (each within the scatter of the next, the first and the last beyond it); then compound 2.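

In this assay, phenoxy in place of phenylsulfanyl on this aromatic carbon gives a 1.5-fold lower number from compound 3 to compound 4 (0.17 log units; within the scatter) and so stays within the scatter, which means these two groups cannot be told apart at this position. The saturated chain carbon bound to the amide-type nitrogen and an aromatic carbon gives the clearer result: hydrogen in place of methyl there gives a 2.5-fold lower number from compound 1 to compound 4 (0.39 log units; beyond the scatter) and lies beyond the scatter, though the step is modest. Nothing available here accounts for either step.

From the compounds shown here alone, it remains open whether an amine or a carboxylic acid on the same aromatic carbon would give a step beyond the scatter. Going by these compounds, it is also open whether the methyl step would look the same alongside phenylsulfanyl, and how an ethyl group on that chain carbon would compare.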